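The compounds below may be only part of what the source reports. "The series", "measured", "known", "first", "only" and "open" are said of these compounds alone.

Compound 1 `COCCN[C@H]1CC[C@H](Nc2cc(-c3csc(OCC4CCOCC4)n3)c(Cl)cn2)CC1`: 570 nM
Compound 2 `COCCN[C@H]1CC[C@H](Nc2cc(-c3csc(SCC4CCOCC4)n3)c(Cl)cn2)CC1`: 340 nM

Among the compounds with values here, in a functional assay on MV4-11 cells (Homo sapiens) for antiproliferative activity, read by CellTiter-Glo, with a stated time of 72 h (a higher number here means a weaker inhibitor of growth, a lower number a stronger inhibitor of growth), compound 2 is not separated from the only other measured value: a 1.7-fold lower number from compound 1 to compound 2 (0.22 log units; within the scatter). Compound 3 `CNc1nc(-c2cc(N[C@H]3CC[C@H](NCCOC)CC3)ncc2Cl)cs1` carries methylamino in place of ((oxan-4-yl)methyl)sulfanyl on an aromatic carbon. Within the data shown here, the one measured step at this place, a 1.7-fold lower number from compound 1 to compound 2 (0.22 log units; within the scatter), keeps the six-membered non-aromatic ring, so no measured step shows that ring leaving. No shift beyond the scatter is therefore expected in this assay, though with wide uncertainty. The expected change is a 1.2-fold higher number from compound 2 to compound 3 (0.07 log units; within the scatter). Compound 3 is estimated at 400 nM (range 80 nM to 2000 nM).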

Compound 3, concentration for 50% growth inhibition: 530 nM
Compound 3: middle estimate off by 1.3-fold (0.12 log units), on the low side; low and high end bracket the measured number.
By their numbers in this assay, from the lowest: compounds 2, 3 and 1 (each within the scatter of the next).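

Loss of the six-membered non-aromatic ring at this aromatic carbon can now be read in this assay: methylamino in place of ((oxan-4-yl)methyl)sulfanyl gives a 1.6-fold higher number from compound 2 to compound 3 (0.19 log units; within the scatter), and methylamino in place of (oxan-4-yl)methoxy gives a 1.1-fold lower number from compound 1 to compound 3 (0.03 log units; within the scatter). The ring is therefore not shown to be required at this position, as compound 1, compound 2 and compound 3 are not separated. No supporting data bear on this result.

From the compounds shown here alone, whether a primary amine, a carboxylic acid or a longer alkyl chain here would move the number beyond the scatter remains open.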